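The source may report more compounds than this note shows. Statements on the series, on what has been measured and on what is new or still open speak of the compounds shown alone.

Compound 1 `Cc1ccc(-n2c(C)cc(-c3nnc4n3CCCCC4)c2C)cc1` gives 34 nM in an assay on isolated protein for inhibition of 15-hydroxyprostaglandin dehydrogenase [NAD(+)] (Homo sapiens), read by fluorescence, with a stated time of 15 min; on this read-out higher numbers stand for weaker inhibition and lower numbers for stronger inhibition.
Compound 2 `Cc1cccc(-n2cnc3cc(C(=O)N4CC(C)CC(C)C4)ccc32)c1` gives 271 nM in this assay.
Compound 3 `Cc1cccc(-n2cnc3cc(C(=O)N4CCC(Br)CC4)ccc32)c1` gives 76 nM in this assay.

Among these three numbers compound 3 stands second highest: its number lies beyond the scatter above that of compound 1 and beyond the scatter below that of compound 2. Among the measured compounds shown here, only one measured step touches the same part of the molecule, the exchange of the group on the carbonyl carbon, which gave a 3.6-fold lower number from compound 2 to compound 3 (0.55 log units; beyond the scatter). Compound 4 `Cc1cccc(-n2cnc3cc(C(=O)N4CCC(C(F)(F)F)CC4)ccc32)c1` differs from compound 3 by trifluoromethyl in place of bromo on a saturated ring carbon. For the measured compounds named here, the single measured step shows that an exchange at that group can shift the number by a modest amount, but it compares two quite different groups, whereas here one group of similar kind replaces another on the same ring carbon. Compound 4 is therefore expected to give a number close to that of compound 3, with a step of a 1.1-fold higher number from compound 3 to compound 4 (0.02 log units; within the scatter) that may well stay within the scatter. The estimate for compound 4 is 80 nM, with a range from 35 nM to 190 nM.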

Compound 4, half-maximal inhibitory concentration: 1520 nM
Beside the measured number, compound 4's estimate is 19-fold (1.28 log units) below it; measured number outside the range, above it.
By their numbers in this assay, from the lowest: compound 1; then compound 3; then compound 2; then compound 4.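

In this assay, trifluoromethyl in place of bromo on this saturated ring carbon gave a 20-fold higher number from compound 3 to compound 4 (1.30 log units; beyond the scatter) and so showed a far larger change than the earlier exchange on the carbonyl carbon, a 3.6-fold lower number from compound 2 to compound 3 (0.55 log units; beyond the scatter). The two groups are alike in carrying no hydrogen-bond donors or acceptors and no net charge, so these counts do not separate them, although the heavy-atom count rises from one to four. Nothing available bears on why the step is so large.

Open, on these data alone, is whether chloro or methyl on the same ring carbon would stay close to compound 3 or move towards compound 4. Equally open, as far as these compounds go, is how a hydroxyl, an amine or a nitrile would fare at this position.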